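Swapping the para substituent: from methoxy to nitro

This account rests on a few compounds, and the source may have more. Where it says the series, first, only, none or still open, it means among the compounds named here.

Measured compounds:
compound 1, `CCOC(=O)c1sc(NC(=O)Cn2cc(-c3cccs3)nn2)nc1C`, 20 nM
compound 2, `CCOC(=O)c1sc(NC(=O)Cn2cc(-c3ccc(F)cc3)nn2)nc1C`, 660 nM
compound 3, `CCOC(=O)c1sc(NC(=O)Cn2cc(-c3ccc(OC)cc3)nn2)nc1C`, 2330 nM

In a functional assay on BMDM cells (Mus musculus, strain C57BL/6) for inhibition, with a stated time of 2 days (a lower number here means a stronger inhibitor, a higher number a weaker inhibitor), compound 3 gives the highest number of the three, so it is the weakest inhibitor here. Its nearest neighbour is compound 2, with a 3.5-fold higher number from compound 2 to compound 3 (0.55 log units; beyond the scatter); furthest is compound 1, with a 120-fold higher number from compound 1 to compound 3 (2.07 log units; beyond the scatter). Compound 4, `CCOC(=O)c1sc(NC(=O)Cn2cc(-c3ccc([N+](=O)[O-])cc3)nn2)nc1C`, has not yet been measured. It differs from compound 3 by nitro in place of methoxy on an aromatic carbon.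

Among the measured compounds shown here, of the steps seen, only the one from compound 2 to compound 3 changes a group on the same aromatic carbon, and it was modest. The two large steps swap the whole ring and say little about a change of one group. One of them is a 33-fold higher number from compound 1 to compound 2 (1.52 log units; beyond the scatter). The other is the step from compound 1 to compound 3 already given. For the measured compounds named here, no measured pair shows nitro, so the direction is open. For compound 4 the expected step is a 1.2-fold lower number from compound 3 to compound 4 (0.07 log units; within the scatter), within or only slightly beyond the scatter. Compound 4 is therefore estimated at 2000 nM, with a range from 500 nM to 8000 nM.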

Compound 4, half-maximal inhibitory concentration: 1840 nM
For compound 4 the middle estimate is 1.1-fold (0.04 log units) above the measured one; the range from low to high includes it.
By their numbers in this assay, from the lowest: compound 1; then compound 2; then compounds 4 and 3 (each within the scatter of the next).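

In this assay nitro and methoxy on this aromatic carbon, para to a large group, cannot be told apart (a 1.3-fold lower number from compound 3 to compound 4 (0.10 log units; within the scatter)), even though the two groups differ in their atoms. Nitro stands apart from fluoro on the same carbon (a 2.8-fold higher number from compound 2 to compound 4 (0.45 log units; beyond the scatter)), so compound 2 has a lower number than both compound 3 and compound 4. The change of the whole ring remains much the larger one (a 92-fold higher number from compound 1 to compound 4 (1.96 log units; beyond the scatter)), and this now holds for all three para-substituted phenyl compounds. Nothing in the data given explains these differences. Still open, as far as these compounds go, is whether an amine or a carboxylic acid on this same carbon would shift the number, and whether any compound with a six-membered ring here could come close to compound 1.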